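Swapping the amine on the side chain of compound 3

The source may hold more compounds than are shown below. What is called first, only, known or untested is meant among the compounds shown, and "the series" means these compounds.

Among the measured compounds shown here, compound 3 `CN(C)CCn1c(=O)sc2cc(S(=O)(=O)Nc3ccccc3)ccc21` gives 21% in an assay on HEK293 cells for displacement of a labelled ligand from 5-hydroxytryptamine receptor 6 (Homo sapiens), read by radioligand binding, with a stated time of 60 min, tested at 100 nM (on this read-out higher numbers stand for more inhibition at the one concentration tested (going by the name of the read-out) and lower numbers for less inhibition), the highest of the three numbers measured so far. Compound 1 `CN(C)CCn1c(=O)sc2cc(S(=O)(=O)N(C)c3ccccc3)ccc21` gives 5% and compound 2 `CN(c1ccccc1)S(=O)(=O)c1ccc2c(c1)sc(=O)n2CCN1CCCCC1` gives 0%; the step of a number 16 percentage points higher from compound 1 to compound 3 (beyond the scatter) sets compound 3 apart from compound 1. Compound 4 `O=c1sc2cc(S(=O)(=O)Nc3ccccc3)ccc2n1CCN1CCCCC1` has not yet been measured. It differs from compound 3 in one place: piperidin-1-yl in place of dimethylamino on a saturated chain carbon, two bonds along the chain from an aromatic nitrogen. The same change has been seen once before, as a number 5 percentage points lower from compound 1 to compound 2 (within the scatter). On that basis no step beyond the scatter is expected in this assay, and the estimated step is a number 4 percentage points lower from compound 3 to compound 4 (within the scatter). Compound 4 is therefore expected to give about 17%, with a likely range from 6% to 28%.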

Compound 4, a percentage reported as inhibition, at one concentration (the size of the read-out at that concentration, not a potency): 7%
Compound 4: the middle estimate sits 10 percentage points above what was measured, within the range that was stated.
By their numbers in this assay, from the lowest: compounds 2, 1 and 4 (each within the scatter of the next); then compound 3.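

On this side chain, piperidin-1-yl in place of dimethylamino can give a step beyond the scatter, a number 14 percentage points lower from compound 3 to compound 4 (beyond the scatter), yet the change reads consistently on both cores: the same change on two cores in this assay, a number 5 percentage points lower (within the scatter) from compound 1 to compound 2 and a number 14 percentage points lower (beyond the scatter) from compound 3 to compound 4, 9 percentage points apart, within the scatter of two such steps. Hydrogen in place of methyl on the sulfonamide nitrogen gives a number 7 percentage points higher from compound 2 to compound 4 (within the scatter) with piperidin-1-yl present, which also agrees with its earlier reading: the same change on two cores in this assay, a number 16 percentage points higher (beyond the scatter) from compound 1 to compound 3 and a number 7 percentage points higher (within the scatter) from compound 2 to compound 4, 9 percentage points apart, within the scatter of two such steps.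

Each compound was read at only one concentration, so these numbers give no potency. On these data alone, whether a morpholine ring or a longer chain to the amine would give more inhibition remains open.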